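This account rests on a few compounds, and the source may have more. Where it says the series, first, only, none or still open, it means among the compounds named here.

Compound 1 `Cc1cc(C(=O)O)nn1-c1ccc(S(=O)(=O)NC(=S)NCc2ccccc2)cc1` is one of three compounds with a result in a functional assay on the whole organism (blood, strain albino) with Mus musculus as the target, with stated times of 6 days and 4 h, at a dose of 0.4 mmol/kg by the oral route; on this read-out lower numbers stand for less inhibition and higher numbers for more inhibition at the one dose given (going by the name of the read-out). In this assay compound 1 gives < 2%, which is a limit of the assay rather than a number. Compound 2 `Cc1cc(C)n(-c2ccc(S(=O)(=O)NC(=S)NCc3ccccc3)cc2)n1` carries methyl in place of carboxy on an aromatic carbon, and in this assay compound 2 gives 0%. The step that the limit leaves unreadable from compound 1 to compound 2 cannot be sized because the limit of < 2% in this assay, at which 1 of the 3 values shown sits, sets a floor under one of the two values. Compound 3 `CCCCNC(=O)NS(=O)(=O)c1ccc(-n2nc(C)cc2C)cc1` gives 2% in this assay.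

Compound 4 `CCCCNC(=S)NS(=O)(=O)c1ccc(-n2nc(C(=O)O)cc2C)cc1` has not yet been measured. It differs from compound 1 by propyl in place of phenyl on a saturated chain carbon bound to an amide-type nitrogen. Within the data shown here, compound 3 carries the same butyl group but differs from compound 4 in more than one place, so no measured step covers this change on its own. All three measured compounds sit at the bottom of the scale in this assay, and the expected step of a number no lower from compound 1 to compound 4 (the limit leaves the size open) is therefore none beyond the scatter. Compound 4 is estimated at 2%, with a range from 0% to 10%.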

Compound 4, a percentage reported as inhibition, in the whole organism at one dose (the size of the read-out at that dose, not a potency): < 1%
Compound 4 was reported as a limit; the forecaster's own chance of this, stated with the estimate: 40%; middle value at least 1 percentage points from the limit.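

Compound 1 and compound 4 are both reported only as limits of the assay, not as numbers, so no step can be read between them. The compounds shown leave open whether replacing phenyl with propyl changes inhibition at all, and whether any change to the shared core produces clear inhibition.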